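A few compounds are considered here, and "the series" means these few. Any claim that something is new, unique, unknown or untested is made for them only; others in the source may bear on it.

In a functional assay on the whole organism for inhibition, with Rattus norvegicus as the target, at a dose of 25 mg/kg by the intraperitoneal route (on this read-out lower numbers stand for less inhibition and higher numbers for more inhibition at the one dose given (going by the name of the read-out)), compound 1 `CCCNc1ncnc2c1ncn2CC1CC1` gives 0%. Compound 2 `CC(C)(C)Nc1ncnc2c1ncn2CC1CC1` gives 0% in this assay, and the step of no change at the digits printed from compound 1 to compound 2 (within the scatter) is flat. Compound 2 thus stands level with compound 1 at the bottom of the scale. Compound 3 `c1ccc(Nc2ncnc3c2ncn3CC2CC2)cc1` differs from compound 2 by phenyl in place of tert-butyl on a nitrogen on an aromatic ring. Within the data shown here, only the step of no change at the digits printed from compound 1 to compound 2 (within the scatter) bears on this change, and it showed nothing; no measured step tells what a ring in this place does. Compound 3 is therefore expected to stay near the floor, with a step of a number 5 percentage points higher from compound 2 to compound 3 (within the scatter) not beyond the scatter. The estimate for compound 3 is 5%, between 0% and 25%.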

Compound 3, a percentage reported as inhibition, in the whole organism at one dose (the size of the read-out at that dose, not a potency): 0%
For compound 3 the middle estimate is 5 percentage points above the measured one; the range from low to high includes it.
By their numbers in this assay, from the lowest: compounds 1, 2 and 3 (each within the scatter of the next).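

In this assay, phenyl on this nitrogen reads the same as the groups without a ring, tert-butyl (no change at the digits printed from compound 2 to compound 3 (within the scatter)) and propyl (no change at the digits printed from compound 1 to compound 3 (within the scatter)). A six-membered aromatic ring of carbon only therefore gives no more of a response here than either of those groups, and this position has yet to show any change in the read-out at this one dose. No measurement at hand offers an explanation for this flat result.

As far as these compounds go, whether a benzyl group or a chain ending in an amine on this nitrogen would lift the reading off the bottom of the scale remains open. So does the question of whether any of these compounds would register at a higher dose.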